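Changing a methyl ester to an ethyl ester on compound 3

This account rests on a few compounds, and the source may have more. Where it says the series, first, only, none or still open, it means among the compounds named here.

Compound 3 `COC(=O)C1=C(C)NC(C)=C(C(=O)OC2CCCC2)C1c1csc(-c2ccc(Cl)cc2)n1` is the middle one of three measured compounds: in an assay on isolated protein for antagonist activity at Voltage-dependent L-type calcium channel subunit alpha-1C (Cavia porcellus), with a stated time of 15 min (a higher number here means a weaker inhibitor, a lower number a stronger inhibitor), compound 3 gives 7290 nM, with compound 1 `CC1=C(C(=O)OC2CCCC2)C(c2csc(-c3ccc(Cl)cc3)n2)C(C(=O)OC2CCCC2)=C(C)N1` at 19000 nM and compound 2 `CCOC(=O)C1=C(C)NC(C)=C(C(=O)OC(C)C)C1c1csc(-c2ccc(Cl)cc2)n1` at 2550 nM. Among the compounds with values here, the one measured step, a 2.6-fold lower number from compound 1 to compound 3 (0.42 log units; beyond the scatter), came from swapping a cyclopentyl ester for a methyl ester. Compound 4 `CCOC(=O)C1=C(C)NC(C)=C(C(=O)OC2CCCC2)C1c1csc(-c2ccc(Cl)cc2)n1` takes the next small step: methyl in place of hydrogen on a saturated chain carbon bound to an oxygen next to a carbonyl group. No measured pair tests exactly this change, but compound 2, carrying an ethyl ester beside an isopropyl ester, gives the lowest number shown, which hints that a small ester is not harmful. A step of a 1.3-fold lower number from compound 3 to compound 4 (0.12 log units; within the scatter) in this assay is therefore expected, in the direction of a lower number or none beyond the scatter. Compound 4 is estimated at 5500 nM, ranging from 2300 nM to 13000 nM.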

Compound 4, half-maximal inhibitory concentration: 8380 nM
Compound 4: the middle estimate sits 1.5-fold (0.18 log units) below what was measured, and the stated range covers the measured number.
By their numbers in this assay, from the lowest: compound 2; then compounds 3 and 4 (each within the scatter of the next); then compound 1.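

In this assay, methyl and ethyl at this ester cannot be told apart: a 1.1-fold higher number from compound 3 to compound 4 (0.06 log units; within the scatter). Changes of larger groups show more, since cyclopentyl in place of isopropyl on the other ester gives a 3.3-fold higher number from compound 2 to compound 4 (0.52 log units; beyond the scatter), and ethyl in place of one cyclopentyl gives a 2.3-fold lower number from compound 1 to compound 4 (0.36 log units; beyond the scatter). No evidence is available to explain these differences. As far as these compounds go, whether this tolerance of methyl and ethyl extends to a longer chain such as propyl, or to a chain ending in an amine, remains open.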